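Replacing the Methoxybenzyl Ether of Compound 1 with a Cyanobenzyl

A few compounds are considered here, and "the series" means these few. Any claim that something is new, unique, unknown or untested is made for them only; others in the source may bear on it.

Of the compounds shown here, three built on a shared core have been tested in a functional assay on HEK293 cells for antagonist activity at proteinase-activated receptor 4 (Homo sapiens), read by FLIPR and calcium flux, with a stated time of 30 min; a higher number here means a weaker inhibitor, a lower number a stronger inhibitor. Compound 1 `COc1cc(OCc2ccccc2OC)c2cc(-c3cn4nc(OC)sc4n3)oc2c1` gives 19 nM in this assay. Compound 3 `COc1nn2cc(-c3cc4c(OC)cccc4o3)nc2s1` gives 7.6 nM, a lower number than compound 1, and the gap between them lies beyond the usual scatter of repeated measurements. Compound 2 `CCSc1nn2cc(-c3cc4ccccc4o3)nc2s1` gives 2900 nM, a far higher number, again well beyond the scatter. Of the three numbers, compound 1 therefore sits second highest, close to compound 3 and very distant from compound 2.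

Compound 4 `COc1cc(OCc2cccc(C#N)c2)c2cc(-c3cn4nc(OC)sc4n3)oc2c1` has not yet been measured. It differs from compound 1 in a single place: 3-cyanophenyl in place of 2-methoxyphenyl on a saturated chain carbon bound to an oxygen on an aromatic ring. Among the compounds with values here, no pair of measured compounds shows this particular change, so there is no direct precedent for its size or direction; the three values only show that this core can reach low numbers and that changes elsewhere can move the number a great deal.

With nothing pointing strongly either way, compound 4 is expected to give 30 nM, with a range from 8 nM to 120 nM. The expected step from compound 1 to compound 4 is a 1.6-fold higher number from compound 1 to compound 4 (0.20 log units; within the scatter), a modest move toward a weaker inhibitor that may not exceed the scatter.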

Compound 4, half-maximal inhibitory concentration: 0.98 nM
For compound 4 the middle estimate is 31-fold (1.49 log units) above the measured one, and the stated range ends above it.
By their numbers in this assay, from the lowest: compound 4; then compound 3; then compound 1; then compound 2.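

In this assay, placing 3-cyanophenyl in place of 2-methoxyphenyl on a saturated chain carbon bound to an oxygen on an aromatic ring gives a 19-fold lower number from compound 1 to compound 4 (1.29 log units; beyond the scatter), so compound 4 is the stronger inhibitor of this pair. Within the data shown here, until now no two measured compounds differed in a single place, so this is the first direct sign that the group at this position can strongly shift the number on the shared core. The shift arrives with no change in the counts of heavy atoms, hydrogen-bond donors or hydrogen-bond acceptors, and nothing measured here accounts for its size or direction.

This one change replaces methoxy with nitrile and also alters the ring number in the group's name from 2 to 3, so the compounds shown leave open how much of the step belongs to each part, a question that 3-methoxyphenyl or 2-cyanophenyl at the same place could address. Also open, as far as these compounds go, is whether a different group there, such as 3-carboxyphenyl or 3-aminophenyl, would keep a number this low.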